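Open-chain hydroxypropyl amides: one chloro removed from the aryl ring

The source may hold more compounds than are shown below. What is called first, only, known or untested is meant among the compounds shown, and "the series" means these compounds.

Compound 1 `O=C(CCC(=O)c1ccc(F)cc1)NCCCO` in a functional assay on the whole organism (Central nervous system) for activation, with Mus musculus as the target (on this read-out higher numbers stand for an effect only at larger amounts of compound and lower numbers for an effect already at smaller amounts), gives 300 mg/kg. Compound 3 `O=C(CCC(=O)c1ccc(Cl)c(Cl)c1)NCCCO` in this assay gives 300 mg/kg, level with compound 1 at the digits shown and within the scatter of it. Compound 2 `O=C1CCCC2(c3ccccc3)OCCCN12`, built on a different core, is reported only at the limit of < 50 mg/kg in this assay, at which 1 of the 3 values shown sits, so the figure for compound 2, < 50 mg/kg, is a limit of the assay and not a number.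

Compound 4 `O=C(CCC(=O)c1ccc(Cl)cc1)NCCCO` differs from compound 3 by hydrogen in place of chloro on an aromatic carbon. Going by the values given here, no measured pair shows this change. Since compound 1 and compound 3 sit together, the expected step is no change at the digits printed from compound 3 to compound 4 (within the scatter), none beyond the scatter. Compound 4 is estimated at 300 mg/kg in this assay, expected within 150 mg/kg to 600 mg/kg.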

Compound 4, dose for half-maximal effect: 300 mg/kg
Compound 4: the middle estimate sits on the measured number at the digits printed; low and high end bracket the measured number.
By their numbers in this assay, from the lowest: compounds 1, 3 and 4 (each within the scatter of the next). At a limit, below all of these: compound 2.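

In this assay hydrogen in place of the chloro meta to a large group gives no change at the digits printed from compound 3 to compound 4 (within the scatter) and so gives this position its first single-change pair. Chloro in place of fluoro on an aromatic carbon gives no change at the digits printed from compound 1 to compound 4 (within the scatter) and adds a second such pair, so among compounds 1, 3 and 4 neither change moves the read-out. Nothing measured here bears on the reason for this.

Going by these compounds, whether an amine, a carboxylic acid or a methoxy group on this aromatic carbon would also leave the read-out in place stays open. So does the effect of a longer chain in place of the hydroxypropyl chain.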